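This account rests on a few compounds, and the source may have more. Where it says the series, first, only, none or still open, it means among the compounds named here.

Of the compounds shown here, two have a number so far in a functional assay on HeLa cells (Homo sapiens) for antiproliferative activity, read by sulforhodamine B assay, with a stated time of 48 h (a lower number here means a stronger inhibitor of growth, a higher number a weaker inhibitor of growth), and they differ in more than one place. Compound 1 (`O=C(NNC(=S)Nc1ccccc1)C1=C(Cl)c2ccccc2CCC1`) gives 3870 nM and compound 2 (`Cc1cc2c(cc1C)C(Cl)=C(c1nnc(-c3ccccc3)o1)CCC2`) gives 4680 nM so the two readings lie within the usual scatter of each other. Compound 2 therefore stands level with compound 1 on these numbers, and two readings say little more than that.

Compound 3 (`Cc1cc2c(cc1C)C(Cl)=C(c1nnc(-c3cccc(I)c3)o1)CCC2`) keeps the shared core of compound 2 and changes it in one place: iodo in place of hydrogen on an aromatic carbon with iodo in place of hydrogen on an aromatic carbon, so that phenyl becomes 3-iodophenyl. Within the data shown here, no pair of measured compounds differs in one place, so the data hold no direct precedent for this change. The expectation rests on compound 2 at 4680 nM as the only reference with the same core. The expected step of a 1.3-fold lower number from compound 2 to compound 3 (0.13 log units; within the scatter) is small, leaning slightly toward stronger inhibition and staying within the scatter. For compound 3 the estimated value is 3500 nM with an expected range of 1200 nM to 10000 nM until the measurement is in.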

Compound 3, concentration for 50% growth inhibition: 4460 nM
For compound 3 the middle estimate is 1.3-fold (0.11 log units) below the measured one; measured number inside the range.
By their numbers in this assay, from the lowest: compounds 1, 3 and 2 (each within the scatter of the next).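

Among these compounds, compounds 1 and 2 differ in more than one place, so compound 3 gives the first one-place comparison in this set: with iodo in place of hydrogen on an aromatic carbon, meta to a large group, this assay shows a 1.0-fold lower number from compound 2 to compound 3 (0.02 log units; within the scatter). Turning phenyl into 3-iodophenyl thus adds one iodine atom at this position without giving a reading that can be told apart from that of compound 2, so at this level of potency the position accepts this single heavy atom in the one case shown. Nothing available bears on why the reading stays within the scatter.

As far as these compounds go, this one change cannot show whether the position is insensitive in general, and it remains open whether a smaller halogen such as fluoro, or a hydroxyl, an amine or a carboxylic acid, on the same aromatic carbon would read as iodo does. Also open, from the compounds shown here alone, is how iodo would read on the other carbons of that phenyl ring, and whether any group there could move the number beyond the scatter.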